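The source may hold more compounds than are shown below. What is called first, only, known or untested is meant among the compounds shown, and "the series" means these compounds.

In an assay on spleen (Cavia porcellus) with leukotriene B4 receptor 1 (Homo sapiens) as the target (on this read-out lower numbers stand for stronger inhibition and higher numbers for weaker inhibition), compound 1 `O=C(O)CCCCCCc1csc(CCCc2ccc(Cl)cc2)c1` gives 1000 nM. In this assay compound 2 `Cc1cc(CCCCCCC(=O)O)c(CCCc2ccccc2)s1` gives 700 nM. In this assay compound 3 `O=C(O)CCCCCCc1ccsc1CCCc1ccc(Cl)cc1` gives 1000 nM.

Among the three measured compounds, compound 2 stands at the lowest number, but its distance from compound 1 and from compound 3 lies within the usual scatter of this kind of measurement, so the three compounds cannot be told apart on these numbers. All three share a chain ending in a carboxylic acid and a second chain bearing a benzene ring, attached to the same kind of sulfur-containing core, and they differ in where the chains sit and in the small groups carried on the rings.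

Compound 4 `Cc1cc(CCCCCC(C)C(=O)O)c(CCCc2ccccc2)s1` has not yet been measured. It differs from compound 2 in one place: methyl in place of hydrogen on a saturated chain carbon bound to a carbonyl carbon and a saturated chain carbon. For the measured compounds named here, no pair of measured compounds shows this same change, so there is no measured step to lean on. The change is small and adds no new donor, acceptor or charge, so the expectation is a step in this assay that stays within the scatter, with no clear direction.

On that basis compound 4 is expected to give 800 nM in this assay, within a range from 300 nM to 2500 nM. The step of a 1.1-fold higher number from compound 2 to compound 4 (0.06 log units; within the scatter) is thus expected to be small.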

Compound 4, half-maximal inhibitory concentration: 300 nM
Estimate against measurement, compound 4: 2.7-fold (0.43 log units) above; measured number inside the range.
By their numbers in this assay, from the lowest: compound 4; then compounds 2, 1 and 3 (each within the scatter of the next).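

Swapping hydrogen for a methyl on the saturated chain carbon bound to a carbonyl carbon and a saturated chain carbon gives a 2.3-fold lower number from compound 2 to compound 4 (0.37 log units; beyond the scatter) in this assay and so means stronger inhibition, a modest step but one beyond the scatter. For the compounds shown here, this is the first sign that this position responds to a change at all, since the earlier compounds offered no step between compounds differing in one place and their numbers could not be told apart. Seen one bond further out, the change reads carboxymethyl to 1-carboxyethyl, so a single added carbon on the acid-bearing chain is enough to move the number, and nothing given here explains why.

Going by these compounds, whether a larger ethyl group, a second methyl or a fluorine on the same chain carbon would lower the number further, leave it unchanged or raise it remains open. On these data alone, it is also open whether the same methyl would produce a similar step on compound 1 or compound 3, which carry a chlorine on the benzene ring and place their chains differently on the shared core.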